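Furan Swapped for Ethyl on the Aryl Nitrogen

A few compounds are considered here, and "the series" means these few. Any claim that something is new, unique, unknown or untested is made for them only; others in the source may bear on it.

Compound 1 `NS(=O)(=O)Oc1ccc2c(c1)CN(C(=O)c1ccc(N(Cc3ccccc3)Cc3ccco3)cc1)CC2` is the reference point of this small series. In an assay on HEK293 cells for inhibition of Steryl-sulfatase (Homo sapiens), tested at 1 uM (on this read-out lower numbers stand for a weaker effect and higher numbers for a stronger effect at the one concentration tested), compound 1 gives 98.2%, the highest of the three numbers recorded. Its nearest neighbour, compound 2 `NS(=O)(=O)Oc1ccc2c(c1)CN(C(=O)c1ccc(N3CCN(Cc4ccccc4)CC3)cc1)CC2`, gives 75.8%, a gap beyond the usual scatter. Compound 3 `CCN(Cc1ccc(F)cc1)c1cccc(C(=O)N2CCc3ccc(OS(N)(=O)=O)cc3C2)c1` gives 66.5%, the lowest of the three and also beyond the scatter from compound 1. No pair among these three differs in only one place, so their values are read side by side, not as single steps.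

Compound 4 `CCCN(Cc1ccccc1)c1ccc(C(=O)N2CCc3ccc(OS(N)(=O)=O)cc3C2)cc1` has not yet been measured. It differs from compound 1 as follows: ethyl in place of furan-2-yl on a saturated chain carbon bound to a nitrogen on an aromatic ring. Cut one bond further out, the same difference reads (furan-2-yl)methyl to propyl; the shared core and the benzyl group on the aryl nitrogen remain.

Within the data shown here, with no measured single-place step available, the expectation rests on the readings themselves. Because compound 1 gives 98.2%, and because compound 2 still gives 75.8% and compound 3 still gives 66.5% with quite different groups on that nitrogen, the expected step is a number 8.2 percentage points lower from compound 1 to compound 4 (within the scatter), small and downward if anything, possibly within the scatter. Compound 4 is therefore estimated at 90%, with a range from 74% to 99%.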

Compound 4, a percentage reported as inhibition, at one concentration (the size of the read-out at that concentration, not a potency): 94.3%
For compound 4 the middle estimate is 4.3 percentage points below the measured one, within the range that was stated.
By their numbers in this assay, from the lowest: compounds 3 and 2 (each within the scatter of the next); then compounds 4 and 1 (each within the scatter of the next).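

In this assay, among these compounds, the exchange of furan-2-yl for ethyl on a saturated chain carbon bound to a nitrogen on an aromatic ring gives the first single-place comparison: a number 3.9 percentage points lower from compound 1 to compound 4 (within the scatter). Among the compounds shown here, at this place, therefore, the five-membered aromatic ring and its hydrogen-bond acceptor can be lost without the reading moving beyond the usual scatter, which the side-by-side values of the earlier compounds could not show. Nothing available explains why the reading holds across this change.

As far as these compounds go, it remains open whether the same place would tolerate an amine or a carboxylic acid in place of the ethyl, or a longer chain such as pentyl, and whether the benzyl group on the aryl nitrogen can be exchanged as freely as the furan-2-yl group was. From the compounds shown here alone, since the read-out gives the size of the effect at one concentration rather than a potency, it also remains open whether the furan-2-yl and ethyl groups would separate in a full concentration series.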